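This account rests on a few compounds, and the source may have more. Where it says the series, first, only, none or still open, it means among the compounds named here.

Compound 1 `Cc1ccc2nc(Cl)c(/C=C/C(=O)c3cccc(Br)c3)cc2c1` carries a chain with a carbonyl that links the shared core to a bromophenyl ring. In an ADME assay on MCF7 cells (Homo sapiens) for cytotoxicity, read by MTT assay, with a stated time of 48 h (on this read-out higher numbers stand for weaker inhibition and lower numbers for stronger inhibition), compound 1 gives only a limit of > 100000 nM, not a number. Compound 2 `C/C(=C\c1cc2cc(C)ccc2nc1Cl)C(=O)c1cccc(Br)c1` is built the same way but has a methyl group on the linking chain. In this assay compound 2 has the entry "not determined" (no result reported), so no result is available for it. The only bearing that exists for this pair comes from the limit of compound 1, described as the limit of > 100000 nM in this assay, at which 1 of the 2 values shown sits.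

Compound 3 `C/C(=C\c1cc2cc(C)ccc2nc1Cl)C(=O)c1cccc(Cl)c1` has not yet been measured. It differs from compound 2 in one place: chloro in place of bromo on an aromatic carbon, in words chloro in place of bromo on an aromatic carbon, or, read one bond further out, 3-bromophenyl to 3-chlorophenyl. Among the compounds with values here, no measured step between a bromo and a chloro compound exists here, so no size or direction can be drawn from the data for this change beyond the usual scatter. On the bearing that compound 1 sits at the limit, compound 3 is expected in this assay to give about 80000 nM, within a range from 20000 nM to 200000 nM, with a real chance that only a limit is reported.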

Compound 3, half-maximal inhibitory concentration: > 100000 nM
Compound 3: no number, only a limit; the forecaster's own chance of this, stated with the estimate: 60%; middle value at least 1.2-fold (0.09 log units) from the limit.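

No step can be read between compound 2 and compound 3: compound 2 has no reported result, and compound 3 gives only a limit, not a number. The compounds shown leave open what actual number any of them would give and whether chloro in place of bromo changes the result, with the data so far resting on a single limit: the limit of > 100000 nM in this assay, at which 2 of the 3 values shown sit.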